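The compounds below may be only part of what the source reports. "The series", "measured", "known", "first", "only" and "open" are said of these compounds alone.

Measured compounds in the series:

compound 1, `Cc1cn(C2CC(N=[N+]=[N-])C(COC(=O)OCCCCCCCCO)O2)c(=O)[nH]c1=O` — 1.14 in a physicochemical assay for lipophilicity; on this read-out lower numbers stand for lower lipophilicity and higher numbers for higher lipophilicity
compound 2, `Cc1cn(C2CC(N=[N+]=[N-])C(COC(=O)OCCCC(=O)OC(C)(C)C)O2)c(=O)[nH]c1=O` — 1.14 in this assay
compound 3, `Cc1cn(C2CC(N=[N+]=[N-])C(COC(=O)CCCC(=O)OC(C)(C)C)O2)c(=O)[nH]c1=O` — 1.17 in this assay

Compound 2 stands level with compound 1 at the digits printed, and together they are the lowest of the three numbers; compound 3 sits a number 0.03 log units higher from compound 1 to compound 3 (within the scatter), which is within the scatter, so the three measured compounds are in practice indistinguishable in this assay.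

The next compound is compound 4, `Cc1cn(C2CC(N=[N+]=[N-])C(COC(=O)OCCCO)O2)c(=O)[nH]c1=O`. Relative to compound 2 the change is hydroxy in place of tert-butoxycarbonyl on a saturated chain carbon, three bonds along the chain from an oxygen next to a carbonyl group.

For the measured compounds named here, the only measured step touching the same position is no change at the digits printed from compound 1 to compound 2 (within the scatter). That step swapped a hydroxy-terminated chain for the tert-butoxycarbonyl group without moving the number. The present change runs the other way but also removes more heavy atoms than it adds: compound 4 carries a 3-hydroxypropyl chain, shorter than the 8-hydroxyoctyl chain of compound 1, so the earlier step is not a direct mirror. The second measured step, a number 0.03 log units higher from compound 1 to compound 3 (within the scatter), concerns the carbonyl carbon and bears little on this change.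

Compound 4 is therefore expected to come in somewhat lower than the measured set, by an estimated a number 0.74 log units lower from compound 2 to compound 4 (beyond the scatter), to 0.4 with a range of 0 to 0.8.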

Compound 4, partition coefficient: -0.98
For compound 4 the middle estimate is 1.38 log units above the measured one; measured number outside the range, below it.
By their numbers in this assay, from the lowest: compound 4; then compounds 1, 2 and 3 (each within the scatter of the next).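

In this assay this chain position proves sensitive after all: hydroxy in place of tert-butoxycarbonyl gives a number 2.12 log units lower from compound 2 to compound 4 (beyond the scatter), whereas the earlier step at the same place, no change at the digits printed from compound 1 to compound 2 (within the scatter), had suggested that the group there hardly mattered. Hydroxy in place of 5-hydroxypentyl at that place gives a number 2.12 log units lower from compound 1 to compound 4 (beyond the scatter), and 3-hydroxypropoxy in place of 3-(tert-butoxycarbonyl)propyl on a carbonyl carbon gives a number 2.15 log units lower from compound 3 to compound 4 (beyond the scatter). Since compound 1 and compound 4 both end in hydroxy, a terminal hydroxy does not by itself set the number in this assay; in this pair the large step goes with the shorter chain, 3-hydroxypropyl against 8-hydroxyoctyl.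

Nothing available bears on why these steps are so large. The compounds shown leave open whether the number climbs evenly or abruptly through chains of intermediate length, such as a 5-hydroxypentyl chain on the same carbonate, and whether an amine or a carboxylic acid at the end of the short chain would track with hydroxy.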